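This account rests on a few compounds, and the source may have more. Where it says the series, first, only, none or still open, it means among the compounds named here.

Measured so far:
- compound 1, `COc1cc(-c2cc(-c3cc(C(C)C)c(O)cc3C)[nH]c(=O)c2C#N)cc(OC)c1OC`: 82%
- compound 2, `COc1ccc(-c2cc(-c3cc(C(C)C)c(O)cc3C)[nH]c(=O)c2C#N)cc1`: 47.5%
- compound 3, `COc1cc(OC)c(-c2cc(-c3cc(C(C)C)c(O)cc3C)[nH]c(=O)c2C#N)c(OC)c1`: 79%

In a functional assay for inhibition, tested at 80 ug/mL (a higher number here means a stronger effect of the compound at the concentration tested, a lower number a weaker effect), compound 2 gives the lowest of the three numbers. Compound 3 lies closest to it, a gap that goes beyond the usual scatter of repeated measurements, and compound 1 lies furthest, also beyond the scatter. Compound 4, `Cc1cc(O)c(C(C)C)cc1-c1cc(-c2ccccc2Cl)c(C#N)c(=O)[nH]1`, has not yet been measured. It differs from compound 2 in one place: 2-chlorophenyl in place of 4-methoxyphenyl on an aromatic carbon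

For the measured compounds named here, no pair of measured compounds differs by exactly this kind of exchange, so no measured step shows which way it should move. The expected step of a number 2.5 percentage points higher from compound 2 to compound 4 (within the scatter) is therefore small and not beyond the scatter. The estimate for compound 4 in this assay is 50%, within a range from 22% to 78%.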

Compound 4, a percentage reported as inhibition, at one concentration (the size of the read-out at that concentration, not a potency): 32%
For compound 4 the middle estimate is 18 percentage points above the measured one; the measured number falls inside the stated range.
By their numbers in this assay, from the lowest: compound 4; then compound 2; then compounds 3 and 1 (each within the scatter of the next).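

In this assay, putting 2-chlorophenyl in place of 4-methoxyphenyl gives a number 15.5 percentage points lower from compound 2 to compound 4 (beyond the scatter), so the read-out responds to a change of aryl group at this position, opposite the ring nitrogen. This single exchange alters both the substituent on the phenyl ring and where it sits, and the step cannot separate the two. No measurement at hand explains the fall.

Still open, from the compounds shown here alone, is how an unsubstituted phenyl would read here, and whether an amine or a carboxylic acid in place of the 2-chlorophenyl would raise or lower the number.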